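The source may hold more compounds than are shown below. What is called first, only, known or untested is meant among the compounds shown, and "the series" means these compounds.

Values in an assay on isolated protein for inhibition of protein kinase C zeta type (Homo sapiens), with stated times of 1 h and 2.5 min, tested at 30 uM; a lower number here means less inhibition, a higher number more inhibition at the concentration tested (going by the name of the read-out):

Compound 1, `CCOC(=O)c1c(-c2ccc(OC)c(OC)c2)csc1NC`: 32%
Compound 2, `CCOC(=O)c1c(-c2ccc(OC)c(OC)c2)csc1NC(N)=O`: 14%
Compound 3, `COCC(C)OC(=O)c1c(-c2ccc(OC)c(OC)c2)csc1N`: 49%

Compound 3 stands highest of the three numbers in this assay; compound 1 is the nearest to it and lies lower beyond the scatter, compound 2 the furthest. Among the measured compounds shown here, the only single-point step measured so far is a number 18 percentage points lower from compound 1 to compound 2 (beyond the scatter), a modest fall that concerns the nitrogen on the aromatic ring, not the ester.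

Compound 4, `COc1ccc(-c2csc(N)c2C(=O)OCc2cccc(C)c2)cc1OC`, differs from compound 3 in 3-methylbenzyl in place of 1-(methoxymethyl)ethyl on an oxygen next to a carbonyl group. For the measured compounds named here, no measured step alters the group on the oxygen next to the carbonyl group: compound 1 and compound 3 differ in two places at once, so their values only show that the pair with the unsubstituted amine and the 1-(methoxymethyl)ethyl ester reads higher, without separating the two changes. Going by the values given here, the step into compound 4 therefore has no direct precedent in this assay, and the expectation is a change of no clear direction, most likely not beyond the scatter, with a wide range.

Compound 4 is estimated at 45% in this assay, in a range of 20% to 70%. The expected step is a number 4 percentage points lower from compound 3 to compound 4 (within the scatter).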

Compound 4, a percentage reported as inhibition, at one concentration (the size of the read-out at that concentration, not a potency): 67%
Compound 4: middle estimate off by 22 percentage points, on the low side; the measured number falls inside the stated range.
By their numbers in this assay, from the lowest: compound 2; then compound 1; then compound 3; then compound 4.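

In this assay, the group on the oxygen next to a carbonyl group proves able to move the read-out by itself: 3-methylbenzyl in place of 1-(methoxymethyl)ethyl gives a number 18 percentage points higher from compound 3 to compound 4 (beyond the scatter). Among the compounds shown here, this is the first step measured at this position, and it shows that an open chain bearing a hydrogen-bond acceptor can be exchanged for a larger group with a six-membered aromatic ring and no acceptor, without loss of inhibition at the concentration tested. No measurement on hand accounts for the rise, so this single pair does not say whether the ring, the size of the group or the absence of the acceptor matters.

Plain benzyl on the same oxygen would show what the ring contributes without the methyl, and a longer chain without a ring, or a carboxylic acid in place of the ester, would test how far the position depends on the aromatic ring and on the ester itself. For the compounds shown here, it also remains open whether 3-methylbenzyl gives a similar step when the nitrogen carries methyl or carbamoyl, and these single-concentration percentages give no potency for any compound.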